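The compounds below may be only part of what the source reports. "The series", "measured", "known", "first", "only" and "open" are said of these compounds alone.

Three compounds have been measured in a functional assay on the whole organism (strain Wistar) for inhibition, with Rattus norvegicus as the target, read by paw edema, with stated times of 30 min and 3 h, at a dose of 20 mg/kg; on this read-out higher numbers stand for more inhibition at the one dose given (going by the name of the read-out) and lower numbers for less inhibition:

compound 1 `CCOC(=O)C1=C(C)NC(C)=C(C(=O)OCC)C1c1ccc(OCC(=O)Nc2c(C)cccc2C)cc1`, 53.9%
compound 2 `CCOC(=O)C1=C(C)NC(C)=C(C(=O)OCC)C1c1ccc(OCC(=O)Nc2ccc(C)cc2)cc1`, 61.1%
compound 3 `CCOC(=O)C1=C(C)NC(C)=C(C(=O)OCC)C1c1ccc(OCC(=O)NNC(=O)c2ccccc2)cc1`, 44.9%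

Compound 3 stands apart only from compound 2: the step of a number 16.2 percentage points lower from compound 2 to compound 3 (beyond the scatter) lies beyond the scatter, whereas the step of a number 9 percentage points lower from compound 1 to compound 3 (within the scatter) stays within it, so the number of compound 3 is not separated from that of compound 1. Compound 4 `CCOC(=O)C1=C(C)NC(C)=C(C(=O)OCC)C1c1ccc(OCC(=O)NNC(=O)c2sccc2Cl)cc1` has not yet been measured; it differs from compound 3 in one place: 3-chlorothiophen-2-yl in place of phenyl on a carbonyl carbon. Going by the values given here, none of the measured steps touches this place. The steps of a number 7.2 percentage points higher from compound 1 to compound 2 (within the scatter), a number 9 percentage points lower from compound 1 to compound 3 (within the scatter) and a number 16.2 percentage points lower from compound 2 to compound 3 (beyond the scatter) all exchange the group on the amide-type nitrogen and leave the carbonyl carbon untouched, so they offer no direct guide, beyond showing that all three numbers fall in a fairly narrow band. With nothing to point in either direction, a step of a number 0.1 percentage points higher from compound 3 to compound 4 (within the scatter) is expected, that is, none beyond the scatter. Compound 4 is therefore estimated at 45% in this assay, with a range from 32% to 58%.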

Compound 4, a percentage reported as inhibition, in the whole organism at one dose (the size of the read-out at that dose, not a potency): 56.3%
The estimate for compound 4 lay 11.3 percentage points below the measured number; the measured number falls inside the stated range.
By their numbers in this assay, from the lowest: compounds 3, 1, 4 and 2 (each within the scatter of the next, the first and the last beyond it).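

In this assay, going by these compounds alone, the exchange of phenyl for 3-chlorothiophen-2-yl on a carbonyl carbon gives a number 11.4 percentage points higher from compound 3 to compound 4 (beyond the scatter) and thus shows that this place, untouched by the earlier steps, can move the number. With this group in place, the ((3-chlorothiophen-2-yl)carbonyl)amino group is not separated from the two groups it is compared with on the amide-type nitrogen, as seen in a number 4.8 percentage points lower from compound 2 to compound 4 (within the scatter) and in a number 2.4 percentage points higher from compound 1 to compound 4 (within the scatter) while benzamido stood apart from 4-methylphenyl. No evidence at hand explains the step at the carbonyl carbon.

The change brings in a sulfur, a chlorine and a five-membered ring at once, and the compounds shown cannot tell which of these goes with the step; plain thiophen-2-yl or 4-chlorophenyl at this place would separate them. From the compounds shown here alone, how an amine or a carboxylic acid on the ring at this place would read also remains open.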